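This account rests on a few compounds, and the source may have more. Where it says the series, first, only, none or still open, it means among the compounds named here.

Compound 1 `COc1ccc(CN(C(=O)Cn2cc(COc3ccc4ccc(=O)oc4c3)nn2)c2cc(OC)c(OC)c(OC)c2)cc1` gives 180 nM
Compound 2 `COc1ccc(CN(C(=O)Cn2cc(CSc3nnnn3C)nn2)c2cc(OC)c(OC)c(OC)c2)cc1` gives 6570 nM

Going by the values given here, in a functional assay on MGC-803 cells (Homo sapiens) for antiproliferative activity, read by MTT assay, with a stated time of 48 h (a lower number here means a stronger inhibitor, a higher number a weaker inhibitor), compound 2 at 6570 nM holds the higher of the two numbers so far. Compound 3 `COc1ccc(CN(C(=O)Cn2cc(CNS(=O)(=O)c3ccc(C)cc3)nn2)c2cc(OC)c(OC)c(OC)c2)cc1` differs from compound 2 by ((4-methylphenyl)sulfonyl)amino in place of (1-methyl-1H-tetrazol-5-yl)sulfanyl on a saturated chain carbon bound to an aromatic carbon and otherwise keeps the shared core. Among the compounds with values here, only one measured step bears on this place. The entering group carries a six-membered aromatic ring of carbon only, as did the group lost in a 37-fold higher number from compound 1 to compound 2 (1.56 log units; beyond the scatter) and that step was large. Within the data shown here, a partial move back towards compound 1 is therefore expected, meaning a lower number than compound 2, though a single step gives little to scale from and the sulfonyl amino link has no measured precedent here. The step expected in this assay is a 4.4-fold lower number from compound 2 to compound 3 (0.64 log units; beyond the scatter) as a middle figure. Compound 3 is estimated at 1500 nM within a range of 300 nM to 7500 nM on this reasoning.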

Compound 3, half-maximal inhibitory concentration: 1580 nM
The estimate for compound 3 lay 1.1-fold (0.02 log units) below the measured number, within the range that was stated.
By their numbers in this assay, from the lowest: compound 1; then compound 3; then compound 2.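

At this place, on a saturated chain carbon bound to an aromatic carbon, this assay now has a second replacement for comparison, and ((4-methylphenyl)sulfonyl)amino gives a 4.2-fold lower number from compound 2 to compound 3 (0.62 log units; beyond the scatter). The number therefore does not depend on the group of compound 1 alone, yet the recovery is only partial, with an 8.8-fold higher number from compound 1 to compound 3 (0.94 log units; beyond the scatter) still separating the two. A six-membered aromatic ring of carbon only is thus not enough here to reach the number of compound 1, whose group also holds a six-membered aromatic ring with a hetero atom, and no measurement available on these compounds accounts for either step.

From the compounds shown here alone, the ring and the sulfonyl amino link enter together in compound 3, so their shares in the step remain open. A phenoxy group and a methylsulfonylamino group at this place would separate the two.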